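Cyclopropyl for isopropyl on the five-membered aromatic ring

A few compounds are considered here, and "the series" means these few. Any claim that something is new, unique, unknown or untested is made for them only; others in the source may bear on it.

Among the compounds with values here, in a functional assay on HEK293 cells for agonist activity at Bile acid receptor (Homo sapiens), read by a luciferase reporter (on this read-out higher numbers stand for an effect only at larger amounts of compound and lower numbers for an effect already at smaller amounts), compound 3 `CC(C)c1onc(-c2c(Cl)cccc2Cl)c1COc1ccc(N(C)Cc2cccc(C(=O)O)c2)c(C(F)(F)F)n1` gives 6 nM, the lowest of the three numbers so far. Compound 1 `CC(C)c1onc(-c2c(Cl)cccc2Cl)c1COc1ccc(N(C)C(=O)c2ccc(C(=O)O)cc2)c(C(F)(F)F)n1` gives 208 nM and compound 2 `CC(C)c1onc(-c2c(Cl)cccc2Cl)c1COc1ccc(NC(=O)c2ccc(C(=O)O)cc2)c(C(F)(F)F)n1` gives 385 nM; the steps among them are a 1.9-fold higher number from compound 1 to compound 2 (0.27 log units; within the scatter), a 35-fold lower number from compound 1 to compound 3 (1.54 log units; beyond the scatter) and a 64-fold lower number from compound 2 to compound 3 (1.81 log units; beyond the scatter). Compound 4 `CN(Cc1cccc(C(=O)O)c1)c1ccc(OCc2c(-c3c(Cl)cccc3Cl)noc2C2CC2)nc1C(F)(F)F` differs from compound 3 by cyclopropyl in place of isopropyl on an aromatic carbon. Within the data shown here, none of the measured steps touches this part of the molecule; all three concern the group on the amide-type nitrogen, so they give no direct guidance. The change is a small one that keeps the overall shape of the molecule, and no step beyond the scatter is expected in this assay, a 1.2-fold higher number from compound 3 to compound 4 (0.07 log units; within the scatter). Compound 4 is therefore estimated at 7 nM, in the range 2.5 nM to 20 nM.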

Compound 4, half-maximal effective concentration: 2 nM
Beside the measured number, compound 4's estimate is 3.5-fold (0.54 log units) above it, outside the stated range (below it).
By their numbers in this assay, from the lowest: compound 4; then compound 3; then compounds 1 and 2 (each within the scatter of the next).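

Cyclopropyl in place of isopropyl next to the ring oxygen gives a 3.0-fold lower number from compound 3 to compound 4 (0.48 log units; beyond the scatter) in this assay, the first reading at this position, as the earlier steps all concerned the group on nitrogen. The two groups have the same heavy-atom count, so this position responds to the ring alone. Nothing measured on these compounds accounts for the step.

Open, from the compounds shown here alone, is whether a cyclobutyl or tert-butyl group here would change the number further. Also open, going by these compounds, is whether cyclopropyl gives a similar step on the amide of compound 1.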